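The source may report more compounds than this note shows. Statements on the series, on what has been measured and on what is new or still open speak of the compounds shown alone.

Compound 1 `CCOC(=O)CCO/N=C(/c1ccc(OC)c(OC)c1OC)c1cccc2ccccc12` was tested in a functional assay on MDA-MB-231 cells (Homo sapiens) for inhibition, read by sulforhodamine B assay, with a stated time of 48 h (a lower number here means a stronger inhibitor, a higher number a weaker inhibitor), and there compound 1 gives 15200 nM. That is the only numeric value among the two shown. The second value belongs to compound 2 `COc1ccc(/C(=C/c2ccc(F)cc2)c2cccc3ccccc23)c(OC)c1OC`, which in this assay reaches only the limit of the assay, > 20000 nM, so no number is known for it. The fact that one of the two values shown sits at that limit is recorded as the limit of > 20000 nM in this assay, at which 1 of the 2 values shown sits, and it means compound 1 stands as the sole measured anchor for what follows.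

Compound 3 `COc1ccc(/C(=N/OCC(=O)O)c2cccc3ccccc23)c(OC)c1OC` is the compound still to be measured. It differs from compound 1 in one place: carboxy in place of (ethoxycarbonyl)methyl on a saturated chain carbon bound to an oxygen on an unsaturated carbon. No pair of measured compounds shows the effect of a change of this kind in this assay, so the size of the step rests on the structural change alone. The expectation for the step from compound 1 to compound 3 in this assay is a modest weakening, a 1.4-fold higher number from compound 1 to compound 3 (0.16 log units; within the scatter), of an extent that may not clear the usual scatter. On that basis compound 3 is estimated in this assay at 22000 nM, with a likely range from 8000 nM to 60000 nM.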

Compound 3, half-maximal inhibitory concentration: > 20000 nM
Compound 3: only a limit was reported (the forecaster's own chance of this, stated with the estimate: 45%); the middle value lies beyond the limit too.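

Compound 3 gives > 20000 nM in this assay, and this is a limit of the assay, not a number. At this position, putting carboxy in place of (ethoxycarbonyl)methyl therefore brings no measurable gain over compound 1, but the size of the change can only be given as a floor, an at least 1.3-fold higher number from compound 1 to compound 3 (0.11 log units; that floor lies within the scatter), so the true step may be negligible or much larger. Among the compounds shown here, compound 3 also adds a further result at the top of the range this assay can read, which leaves compound 1 as the only compound here with an actual number: the limit of > 20000 nM in this assay, at which 2 of the 3 values shown sit.

The compounds shown leave open whether the shorter chain or the loss of the ethyl ester matters more, since 2-(ethoxycarbonyl)ethyl to carboxymethyl changes both at once, and a carboxylic acid on the longer chain, or the ethyl ester on the shorter one, would separate the two. They also leave open whether an amine or a primary amide at the end of this chain would give a value below the limit.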